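This account rests on a few compounds, and the source may have more. Where it says the series, first, only, none or still open, it means among the compounds named here.

Of the compounds shown here, three built on one shared core have been tested in a functional assay on CHO cells with adenosine receptor A1 (Homo sapiens) as the target, read by cAMP accumulation and immunoassay, with a stated time of 6 min, tested at 1 uM; on this read-out higher numbers stand for a weaker effect at the one concentration tested and lower numbers for a stronger effect. Compound 1 `CC(C)N1CCN(Cc2csc(N)c2C(=O)c2ccc(Cl)cc2)CC1` gives 7.3%, the top of the three numbers, though compound 3 sits within the scatter of it. Compound 3 `Nc1scc(CN2CCN(C3CCCCCC3)CC2)c1C(=O)c1ccc(Cl)cc1` gives 3.7%, and compound 2 `Nc1scc(CN2CCN(c3cc(Cl)cc(Cl)c3)CC2)c1C(=O)c1ccc(Cl)cc1` gives -69%. Between the first two the difference is small: a number 3.6 percentage points lower from compound 1 to compound 3 (within the scatter). Against compound 2 the gap is wide: a number 76.3 percentage points lower from compound 1 to compound 2 (beyond the scatter), and in the same way a number 72.7 percentage points higher from compound 2 to compound 3 (beyond the scatter).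

Compound 4 `Nc1scc(CN2CCN(c3cccc(F)c3)CC2)c1C(=O)c1ccc(Cl)cc1` differs from compound 1 in one place. 3-fluorophenyl in place of isopropyl on an amine nitrogen in a ring

The two earlier changes at that same place pull in different directions. Putting cycloheptyl, a non-aromatic group, in place of isopropyl left the number essentially unchanged, while putting the aromatic 3,5-dichlorophenyl there lowered it by a wide margin. Compound 4 carries an aromatic ring at that place, as compound 2 does, though with one fluorine rather than two chlorines, so a step downward beyond the scatter is expected, its full size uncertain because only compound 2 with -69% shows an aromatic group there. The expected step is a number 37.3 percentage points lower from compound 1 to compound 4 (beyond the scatter). Compound 4 is therefore estimated at -30%, within a range from -70% to 10%.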

Compound 4, a percentage reported as activity, at one concentration (the size of the read-out at that concentration, not a potency): -86%
Compound 4: the middle estimate sits 56 percentage points above what was measured; measured number outside the range, below it.
By their numbers in this assay, from the lowest: compound 4; then compound 2; then compounds 3 and 1 (each within the scatter of the next).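

In this assay, the low number no longer rests on compound 2 alone: a second aromatic ring on the amine nitrogen gives a number 93.3 percentage points lower from compound 1 to compound 4 (beyond the scatter), and against the other non-aromatic group it gives a number 89.7 percentage points lower from compound 3 to compound 4 (beyond the scatter), so among these four compounds the two carrying an aromatic ring at this place stand apart from the two without one, and none goes against this. The two chlorines are not needed for the low number, as 3-fluorophenyl in place of 3,5-dichlorophenyl gives a number 17 percentage points lower from compound 2 to compound 4 (beyond the scatter), a modest step that is still beyond the scatter. No separate measurement is available to explain the link between an aromatic ring at this place and the lower number.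

As far as these compounds go, it remains open whether the ring needs a halogen at all, which a plain phenyl group at this place would address. Also open, from the compounds shown here alone, is whether a benzyl group there would behave like the two aromatic groups or like isopropyl and cycloheptyl.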